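The source may report more compounds than this note shows. Statements on the series, on what has been measured and on what is new or still open speak of the compounds shown alone.

Compound 1 `CC[C@H](C)[C@H](N)CN(C(=O)[C@@H]1C[C@H]1c1cccc(Cl)c1)c1ccc(-c2ccccc2)cc1`: 2200 nM; compound 2 `CC[C@H](C)[C@H](N)CN(C(=O)[C@@H]1C[C@H]1c1ncc(C)s1)c1ccc(-c2ccccc2)cc1`: 1300 nM; compound 3 `CC(C)C[C@H](N)CN(C(=O)[C@@H]1C[C@H]1c1ccccc1)c1ccc(-c2ccncc2)cc1`: 13000 nM, all in a functional assay for agonist activity at G protein-coupled receptor 88 (Homo sapiens), read by HTRF and cAMP accumulation; on this read-out lower numbers stand for an effect already at smaller amounts and higher numbers for an effect only at larger amounts of compound.

Compound 3 gives the highest number of the three in this assay, with compounds 1 and 2 both beyond the scatter below it. Compound 4 `COc1cccc(-c2ccc(N(C[C@@H](N)CC(C)C)C(=O)[C@@H]3C[C@H]3c3ccccc3)cc2)c1` arises from compound 3 by 3-methoxyphenyl in place of pyridin-4-yl on an aromatic carbon. Among the compounds with values here, the only measured step, a 1.7-fold lower number from compound 1 to compound 2 (0.23 log units; within the scatter), concerns a different position and a different kind of group, so it bears only loosely on this change. That compounds 1 and 2, which lack the pyridin-4-yl, sit well below compound 3 suggests a drop; compound 4 is therefore expected to give 3000 nM, between 1000 nM and 10000 nM, a step of a 4.3-fold lower number from compound 3 to compound 4 (0.64 log units; beyond the scatter).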

Compound 4, half-maximal effective concentration: 1100 nM
Compound 4: middle estimate off by 2.7-fold (0.44 log units), on the high side; low and high end bracket the measured number.
By their numbers in this assay, from the lowest: compounds 4, 2 and 1 (each within the scatter of the next); then compound 3.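

In this assay, 3-methoxyphenyl in place of pyridin-4-yl on an aromatic carbon, para to a large group, gives a 12-fold lower number from compound 3 to compound 4 (1.07 log units; beyond the scatter), a large step. This position therefore responds to a change of aromatic group beyond the scatter, which the earlier step on the saturated ring carbon did not show. Nothing at hand accounts for the size of this step.

With both the ring nitrogen and the methoxy group changing at once, the compounds shown do not separate their shares of the step. From the compounds shown here alone, how a hydroxyl or a dimethylamino group in place of the methoxy would read out also stays open.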